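Estimating a 4-cyanophenyl swap on compound 1

The source may hold more compounds than are shown below. What is called first, only, known or untested is meant among the compounds shown, and "the series" means these compounds.

Compound 1 `COc1cc(/C=C2\CN(C)C/C(=C\c3ccccc3F)C2=O)cc(OC)c1` gives 1240 nM
Compound 2 `CN1C/C(=C\c2ccc(C(C)(C)C)cc2)C(=O)/C(=C/c2ccccc2F)C1` gives 9120 nM
Compound 3 `CN1C/C(=C\c2cccc([N+](=O)[O-])c2)C(=O)/C(=C/c2ccccc2F)C1` gives 1080 nM

These three numbers all come from a functional assay on HepG2 cells (Homo sapiens) for cytotoxicity, read by MTT assay, with a stated time of 24 h (on this read-out lower numbers stand for stronger inhibition and higher numbers for weaker inhibition), and describe compounds that share a 2-fluorophenyl group, while the group on the other side of the shared core varies. Compound 1 (at 1240 nM) lies within the usual scatter of compound 3 (at 1080 nM), so these two cannot be ranked. Compound 2 (at 9120 nM) has a clearly higher number than either, meaning weaker inhibition.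

Compound 4 `COc1cc(/C=C2\CN(C)C/C(=C\c3ccc(C#N)cc3)C2=O)cc(OC)c1` has not yet been measured. It matches compound 1 except for 4-cyanophenyl in place of 2-fluorophenyl on a double-bonded chain carbon bound to a double-bonded ring carbon, a difference counted as 4-cyanophenyl in place of 2-fluorophenyl on a double-bonded chain carbon bound to a double-bonded ring carbon in full.

Among the compounds with values here, no measured compound shows what happens when the 2-fluorophenyl group is replaced, so the data offer no direct guide to this change. The starting point is therefore compound 1 itself, at 1240 nM in this assay as its closest measured relative. The estimated step of a 1.1-fold higher number from compound 1 to compound 4 (0.05 log units; within the scatter) is expected to stay within the scatter, with no firm direction. Compound 4 is estimated at 1400 nM with an expected range of 500 nM to 4500 nM in this measurement.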

Compound 4, half-maximal inhibitory concentration: 880 nM
Compound 4: the middle estimate sits 1.6-fold (0.20 log units) above what was measured; low and high end bracket the measured number.
By their numbers in this assay, from the lowest: compounds 4, 3 and 1 (each within the scatter of the next); then compound 2.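

In this assay, replacing 2-fluorophenyl with 4-cyanophenyl gives a 1.4-fold lower number from compound 1 to compound 4 (0.15 log units; within the scatter) so compound 1 and compound 4 cannot be ranked. Within the data shown here, this is the first view of the 2-fluorophenyl side of the shared core, since the earlier compounds varied only the group on the other side, and it shows that a quite different aryl group, carrying a nitrile and no fluorine, can sit on this double-bonded chain carbon without a change that stands out from the scatter. No supporting measurement is available to explain this result.

This single swap changes both the substituent and its printed ring position, so the compounds shown cannot separate the loss of fluorine from the arrival of the nitrile, and they cannot say whether 4-fluorophenyl or 2-cyanophenyl would behave in the same way. They also leave open whether a phenyl ring carrying an amine or a carboxylic acid, or an unsubstituted phenyl ring, would stay within the scatter of compound 1 at this place.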